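This account rests on a few compounds, and the source may have more. Where it says the series, first, only, none or still open, it means among the compounds named here.

Compound 1, `CCCCNc1nc(C(F)(F)F)ccc1CNC(=O)C(C)c1ccc(NS(C)(=O)=O)c(F)c1`, gives 9.1 nM in a functional assay on CHO-K1 cells for antagonist activity at transient receptor potential cation channel subfamily V member 1 (Homo sapiens), read by FLIPR; on this read-out higher numbers stand for weaker inhibition and lower numbers for stronger inhibition.
Compound 2, `CC(C(=O)NCc1ccc(C(F)(F)F)nc1Nc1ccccc1)c1ccc(NS(C)(=O)=O)c(F)c1`, gives 59.6 nM in this assay.
Compound 3, `CCCCN(C)c1nc(C(F)(F)F)ccc1CNC(=O)C(C)c1ccc(NS(C)(=O)=O)c(F)c1`, gives 0.8 nM in this assay.

Compound 4, `CC(C(=O)NCc1ccc(C(F)(F)F)nc1N(C)c1ccccc1)c1ccc(NS(C)(=O)=O)c(F)c1`, has not been measured. It differs from compound 3 by phenyl in place of butyl on a nitrogen on an aromatic ring. The same kind of change, (phenyl in place of butyl on a nitrogen on an aromatic ring), is already measured once, where it gave a 6.5-fold higher number from compound 1 to compound 2 (0.82 log units; beyond the scatter). The two cores differ by methyl in place of hydrogen on a nitrogen on an aromatic ring, which on its own gave an 11-fold lower number from compound 1 to compound 3 (1.06 log units; beyond the scatter); the place of the change is not the same word for word, since in compound 1 the nitrogen's other neighbour is only an aromatic carbon, while in compound 3 it is an aromatic carbon and a saturated chain carbon. The step from compound 2 to compound 3 was a 75-fold lower number from compound 2 to compound 3 (1.87 log units; beyond the scatter), so the two changes do not simply add. Compound 4 is therefore expected to show a 6.3-fold higher number from compound 3 to compound 4 (0.80 log units; beyond the scatter), resting on the step from compound 1 to compound 2, with some added uncertainty from the different place. The estimate for compound 4 in this assay is 5 nM, expected between 1.5 nM and 20 nM.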

Compound 4, inhibition constant: 0.9 nM
Estimate against measurement, compound 4: 5.6-fold (0.74 log units) above; measured number below the stated range.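

In this assay, phenyl in place of butyl on a nitrogen on an aromatic ring gives a 1.1-fold higher number from compound 3 to compound 4 (0.05 log units; within the scatter) when that nitrogen also carries methyl, a step within the scatter, so the loss seen on the core of compound 1 does not carry over to the core of compound 3: the same change on two cores in this assay, a 6.5-fold higher number (0.82 log units; beyond the scatter) from compound 1 to compound 2 and a 1.1-fold higher number (0.05 log units; within the scatter) from compound 3 to compound 4, 5.8-fold (0.77 log units) apart, beyond the scatter of two such steps
Read the other way, methyl in place of hydrogen on that nitrogen gives a 66-fold lower number from compound 2 to compound 4 (1.82 log units; beyond the scatter), and this step does not match the one seen with butyl on the nitrogen: the same change on two cores in this assay, an 11-fold lower number (1.06 log units; beyond the scatter) from compound 1 to compound 3 and a 66-fold lower number (1.82 log units; beyond the scatter) from compound 2 to compound 4, 5.8-fold (0.77 log units) apart, beyond the scatter of two such steps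
Together with a 10-fold lower number from compound 1 to compound 4 (1.00 log units; beyond the scatter), these steps show that the two changes do not act independently among these compounds, but four compounds cannot show why, or whether the same holds for other groups on that nitrogen.

The compounds shown leave open whether a propyl chain, a cyclohexyl ring or a chlorophenyl group on that nitrogen would follow butyl or phenyl. They also leave open whether ethyl in place of the methyl would give the same result.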